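Working notes: from compound 2 to compound 3

This account rests on a few compounds, and the source may have more. Where it says the series, first, only, none or still open, it means among the compounds named here.

Measured in an ADME assay for permeability, using PAMPA, with a stated time of 4 h, at pH 7.4; a lower number here means that the compound crosses the layer more slowly, a higher number that the compound crosses the layer faster:
- compound 1 `NC(=O)NCCCCN(C[C@H]1Cc2ncccc2CN1)[C@H]1CCCc2cccnc21`: 2 nm/s
- compound 2 `CN(CCCCN(C[C@H]1Cc2ncccc2CN1)[C@H]1CCCc2cccnc21)C1CCC(F)(F)CC1`: 310 nm/s

Among the compounds with values here, compound 2 stands highest of the two, with compound 1 as its only neighbour, far lower. Next comes compound 3 `c1cnc2c(c1)CN[C@@H](CN(CCCCNC1CCOCC1)[C@H]1CCCc3cccnc31)C2`, not yet measured, which differs from compound 2 as follows: a group of 7 heavy atoms (5 carbon, 1 nitrogen, 1 oxygen; one six-membered non-aromatic ring with 1 hetero atom) in place of a group of 10 heavy atoms (7 carbon, 1 nitrogen, 2 fluorine; one six-membered non-aromatic ring of carbon only), on a saturated chain carbon, four bonds along the chain from an amine nitrogen. Within the data shown here, one measured step bears on this change, at the same place on the chain: a 160-fold higher number from compound 1 to compound 2 (2.19 log units; beyond the scatter), large and beyond the scatter. Among the measured compounds shown here, no measured compound carries the (oxan-4-yl)amino group, so this single step is a loose guide. A lower number is expected in this assay, in a sizeable step but a smaller one than that measured, which would leave compound 3 above compound 1 at 2 nm/s. The estimated step is a 12-fold lower number from compound 2 to compound 3 (1.09 log units; beyond the scatter). For compound 3 the expected value is 25 nm/s, with an estimated range of 4 nm/s to 120 nm/s.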

Compound 3, apparent permeability: 8 nm/s
Compound 3: middle estimate off by 3.1-fold (0.49 log units), on the high side; low and high end bracket the measured number.
By their numbers in this assay, from the lowest: compound 1; then compound 3; then compound 2.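

At the saturated chain carbon, four bonds along the chain from an amine nitrogen, a second replacement now gives a large step in this assay (a 39-fold lower number from compound 2 to compound 3 (1.59 log units; beyond the scatter)), so the high number of compound 2 does not carry over to this other six-membered ring. Within the data shown here, on the amine nitrogen, oxan-4-yl in place of carbamoyl gives only a modest step (a 4.0-fold higher number from compound 1 to compound 3 (0.60 log units; beyond the scatter)), far smaller than the one to the group of compound 2 (a 160-fold higher number from compound 1 to compound 2 (2.19 log units; beyond the scatter)). No measured evidence on the cause accompanies these numbers.

The step to compound 3 exchanges the ring and adds a hydrogen-bond donor in one move, and the compounds shown do not separate the two. A methyl on the (oxan-4-yl)amino nitrogen, or a plain cyclohexyl ring without fluorine, would bear on that question.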